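The source may hold more compounds than are shown below. What is called first, only, known or untested is meant among the compounds shown, and "the series" means these compounds.

Compound 1 `COc1ccc(N/C=C\C(=O)c2nc(-c3ccc(F)cc3)n3ccccc23)cc1` and compound 2 `COc1ccc(N/C=C\C(=O)c2nc(-c3ccc(F)cc3)n3ccccc23)cc1OC` share the same core and differ only in a methoxy group on an aromatic carbon. In a functional assay on MDA-MB-231 cells (Homo sapiens) for cytotoxicity, read by MTT assay, with a stated time of 48 h (on this read-out higher numbers stand for weaker inhibition and lower numbers for stronger inhibition), compound 1 gives > 30000 nM, which is a limit of the assay and not a measured number. Compound 2 gives > 30000 nM in this assay, again a limit rather than a number. The step that the two limits leave unreadable from compound 1 to compound 2 therefore cannot be read in size or direction; both values rest on the same limit (the limit of > 30000 nM in this assay, at which 2 of the 2 values shown sit). Compound 2 thus stands at the edge of what this assay can report, with no number of its own.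

Compound 3 `O=C(/C=C\Nc1ccc(Cl)cc1)c1nc(-c2ccc(F)cc2)n2ccccc12` has not been measured. Relative to compound 2 it carries 4-chlorophenyl in place of 3,4-dimethoxyphenyl on an amine nitrogen. No readable measured step bears on this change, so the available data give no guidance on how large a shift to expect in this assay, nor in which direction. Compound 3 is expected to remain at the limit as well, with an estimated value of 30000 nM and a range from 5000 nM to 100000 nM. The expected step of a number no higher from compound 2 to compound 3 (the limit leaves the size open) is therefore one of no clear size.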

Compound 3, half-maximal inhibitory concentration: 4250 nM
For compound 3 the middle estimate is 7.1-fold (0.85 log units) above the measured one; measured number below the stated range.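

In this assay, the group on the amine nitrogen proves able to move the read-out, which the two methoxy-bearing compounds could not show: 4-chlorophenyl in place of 3,4-dimethoxyphenyl gives an at least 7.0-fold lower number from compound 2 to compound 3 (0.84 log units; beyond the scatter). Chloro in place of methoxy on an aromatic carbon gives an at least 7.0-fold lower number from compound 1 to compound 3 (0.84 log units; beyond the scatter), so compound 3 is the only one of the three with a number of its own and the first sign of cytotoxicity that can be placed on this scale. Both steps give only a minimum size, and the step between the two methoxy-bearing compounds cannot be read, because the values of compound 1 and compound 2 are limits and not numbers: the limit of > 30000 nM in this assay, at which 2 of the 3 values shown sit.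

The compounds shown leave open whether the chloro group itself matters or whether the loss of methoxy is enough, and a plain phenyl on the amine nitrogen would help to separate these two readings. They also leave open how a bromo or trifluoromethyl group in place of chloro would behave, and whether a non-aromatic group such as cyclohexyl would be tolerated at this nitrogen.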